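The source may hold more compounds than are shown below. What is called first, only, known or untested is meant among the compounds shown, and "the series" means these compounds.

Measured so far in an ADME assay on MT4 cells (Homo sapiens) for cytotoxicity, read by MTT assay, with a stated time of 4 days; on this read-out higher numbers stand for lower toxicity in this test and lower numbers for higher toxicity in this test: compound 1 `O=C(COc1cccc2ccccc12)N/N=C/c1ccc(Cl)cc1` gives 87.6 ug/mL, and compound 2 `C/C(=N\NC(=O)COc1cccc2ccccc12)c1ccc(C#N)cc1Br` gives 12.1 ug/mL.

Compound 2 stands lowest of the two numbers shown; its only neighbour, compound 1, sits well above it, beyond the scatter. Compound 3 `C/C(=N\NC(=O)COc1cccc2ccccc12)c1ccc([N+](=O)[O-])cc1` differs from compound 2 in one place: 4-nitrophenyl in place of 2-bromo-4-cyanophenyl on a carbon with a double bond to nitrogen. Among the measured compounds shown here, no step between two measured compounds isolates this change, so the direction rests on little. A modest rise in this assay is expected, a 2.5-fold higher number from compound 2 to compound 3 (0.39 log units; beyond the scatter), though none beyond the scatter would not surprise. Compound 3 is therefore estimated at 30 ug/mL, in a range from 8 ug/mL to 110 ug/mL.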

Compound 3, half-maximal cytotoxic concentration: 89.3 ug/mL
Beside the measured number, compound 3's estimate is 3.0-fold (0.47 log units) below it; the measured number falls inside the stated range.
By their numbers in this assay, from the lowest: compound 2; then compounds 1 and 3 (each within the scatter of the next).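

In this assay, among the compounds shown here, 4-nitrophenyl in place of 2-bromo-4-cyanophenyl on a carbon with a double bond to nitrogen gives a 7.4-fold higher number from compound 2 to compound 3 (0.87 log units; beyond the scatter), the first isolated change at this position, and it moves the number beyond the scatter. The two groups have equal heavy-atom counts, so that count does not separate them. No measurement at hand explains the step.

The step swaps the whole group at once, leaving open whether the bromine or the nitrile of compound 2 goes with its lower number. As far as these compounds go, how an amine or a carboxylic acid in this place would read also stays open.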